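Quinoline aryl ureas: trifluoromethyl to chloro swap

A few compounds are considered here, and "the series" means these few. Any claim that something is new, unique, unknown or untested is made for them only; others in the source may bear on it.

Measured so far:
Compound 1 `COc1cc2cc(Oc3ccc(NC(=O)Nc4cccc(C(F)(F)F)c4)cc3)c(C)nc2cc1OC`: in a functional assay on SW-620 cells (Homo sapiens) for inhibition, read by sulforhodamine B assay, with a stated time of 48 h (a lower number here means that less compound is tolerated, a higher number that more compound is tolerated), compound 1 gives > 50000 nM, which is a limit of the assay and not a number.
Compound 2 `COc1cc2cc(Oc3ccc(NC(=O)Nc4ccc(Cl)c(C(F)(F)F)c4)cc3)c(C)nc2cc1OC`: in this assay compound 2 gives 14000 nM.

Compound 2 thus holds the only number shown in this assay; the other value sits at the limit of > 50000 nM in this assay, at which 1 of the 2 values shown sits. Going by the values given here, the one measured step, an at least 3.5-fold lower number from compound 1 to compound 2 (0.55 log units; beyond the scatter), is the gain of a chloro group on the aromatic ring of the urea tail, and it reaches at least modest size.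

Compound 3 `COc1cc2cc(Oc3ccc(NC(=O)Nc4ccc(Cl)c(Cl)c4)cc3)c(C)nc2cc1OC` differs from compound 2 by chloro in place of trifluoromethyl on an aromatic carbon. Among the compounds with values here, no measured step tests an exchange of trifluoromethyl for chloro; the step from compound 1 to compound 2 only shows that the chloro that both compounds share matters. Within the data shown here, with no direct precedent, the expectation for this assay is a step of small size, if any, leaning toward a slightly higher number, with a fair chance that only a limit is reported. Compound 3 is therefore estimated at 20000 nM, range 7000 nM to 60000 nM. The expected step of a 1.4-fold higher number from compound 2 to compound 3 (0.15 log units; within the scatter) is estimated to stay close to the scatter.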

Compound 3, concentration lethal to 50% of the cells: 60900 nM
Compound 3: the middle estimate sits 3.0-fold (0.48 log units) below what was measured, and the stated range ends below it.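

Chloro in place of trifluoromethyl, on the carbon ortho to a chloro group, gives a 4.4-fold higher number from compound 2 to compound 3 (0.64 log units; beyond the scatter) in this assay, so the trifluoromethyl group contributes to the lower number of compound 2 and is not freely exchanged for chloro here. Together with an at least 3.5-fold lower number from compound 1 to compound 2 (0.55 log units; beyond the scatter), this shows that the 4-chloro-3-(trifluoromethyl)phenyl tail of compound 2 differs from both of its one-place neighbours, and the chloro that compound 2 and compound 3 share does not by itself bring the number down to that of compound 2. The step between compound 1 and compound 3 cannot be read, because compound 1 stands at a limit of the assay and gives no number: the limit of > 50000 nM in this assay, at which 1 of the 3 values shown sits.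

Still open, from the compounds shown here alone, is whether a different group in place of the trifluoromethyl, such as a nitrile, a methyl or a bromo, would stay near compound 2 at 14000 nM or move toward compound 3 at 60900 nM. Also open, going by these compounds, is whether the same exchange reads alike on a core carrying an amine or a carboxylic acid in place of the methyl group.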